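Swapping Pyridin-3-yl for 2-Fluorophenyl on the Shared Core

This account rests on a few compounds, and the source may have more. Where it says the series, first, only, none or still open, it means among the compounds named here.

Of the compounds shown here, three built on one shared core have been tested in a functional assay on HepG2 cells (Homo sapiens) for antiproliferative activity, read by MTT assay; on this read-out lower numbers stand for stronger inhibition and higher numbers for weaker inhibition. Compound 1 `COc1ccc(/C=C2/SC(N3CCC[C@H]3C(=O)Nc3ccc4ncnc(Nc5cccc(Cl)c5)c4c3)=NC2=O)cc1` gives 19000 nM. Compound 2 `O=C1N=C(N2CCC[C@H]2C(=O)Nc2ccc3ncnc(Nc4cccc(Cl)c4)c3c2)S/C1=C/c1cccnc1` gives 8500 nM, the lowest of the three numbers. Compound 3 `COc1ccccc1/C=C1/SC(N2CCC[C@H]2C(=O)Nc2ccc3ncnc(Nc4cccc(Cl)c4)c3c2)=NC1=O` gives 22100 nM. The steps among them are modest at most: a 2.2-fold lower number from compound 1 to compound 2 (0.35 log units; beyond the scatter), a 1.2-fold higher number from compound 1 to compound 3 (0.07 log units; within the scatter), and a 2.6-fold higher number from compound 2 to compound 3 (0.41 log units; beyond the scatter).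

Compound 4 `O=C1N=C(N2CCC[C@H]2C(=O)Nc2ccc3ncnc(Nc4cccc(Cl)c4)c3c2)S/C1=C/c1ccccc1F` differs from compound 2 in one place: 2-fluorophenyl in place of pyridin-3-yl on a double-bonded chain carbon bound to a double-bonded ring carbon. Going by the values given here, two measured steps bear on this change, since each sets a carbon-only ring where compound 2 carries pyridin-3-yl: a 2.6-fold higher number from compound 2 to compound 3 (0.41 log units; beyond the scatter), and, read in reverse, a 2.2-fold lower number from compound 1 to compound 2 (0.35 log units; beyond the scatter). Both point to a modest rise in the number when the pyridin-3-yl is given up. Accordingly, compound 4 is expected to show a modest rise in this assay, a 2.1-fold higher number from compound 2 to compound 4 (0.33 log units; beyond the scatter). The estimate for compound 4 is 18000 nM, with a range from 8000 nM to 40000 nM.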

Compound 4, half-maximal inhibitory concentration: 18200 nM
Compound 4: the middle estimate sits 1.0-fold (0.00 log units) below what was measured; low and high end bracket the measured number.
By their numbers in this assay, from the lowest: compound 2; then compounds 4, 1 and 3 (each within the scatter of the next).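

On the double-bonded chain carbon, 2-fluorophenyl also fails to match pyridin-3-yl in this assay and the measured step is a 2.1-fold higher number from compound 2 to compound 4 (0.33 log units; beyond the scatter) so compound 2 now stands apart from three different carbon-only rings, with none of the four compounds going against that. Among those rings, the substituent makes no visible difference: fluoro in place of methoxy gives a 1.2-fold lower number from compound 3 to compound 4 (0.08 log units; within the scatter) and 2-fluorophenyl in place of 4-methoxyphenyl gives a 1.0-fold lower number from compound 1 to compound 4 (0.02 log units; within the scatter) and both steps lie within the scatter. Nothing available here explains why pyridin-3-yl stands apart.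

The compounds shown leave open whether plain phenyl would fall with these carbon-only rings. They also leave open whether pyridin-4-yl or pyrimidin-5-yl would hold the number of compound 2 or lower it further.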